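The source may hold more compounds than are shown below. What is called first, only, known or untested is meant among the compounds shown, and "the series" means these compounds.

Of the compounds shown here, three built on one shared core have been measured in a functional assay on HT-29 cells (Homo sapiens) for inhibition, read by MTT assay, with a stated time of 48 h; on this read-out higher numbers stand for weaker inhibition and lower numbers for stronger inhibition. Compound 1 `Cc1ccc(NC(=S)NC(=O)c2ccc(OCc3ccccc3)cc2)cc1-c1nc2ccccc2[nH]1` gives 28800 nM in this assay. Compound 2 `Cc1ccc(NC(=S)NC(=O)c2ccc(OCc3ccc(C(F)(F)F)cc3)cc2)cc1-c1nc2ccccc2[nH]1` gives 17600 nM in this assay, and compound 3 `Cc1ccc(NC(=S)NC(=O)c2ccc(OCc3cccc(F)c3)cc2)cc1-c1nc2ccccc2[nH]1` gives 55300 nM in this assay. Compound 2 holds the lowest number of the three: its step from compound 1 is a 1.6-fold lower number from compound 1 to compound 2 (0.21 log units; within the scatter), which stays within the scatter, whereas a 3.1-fold higher number from compound 2 to compound 3 (0.50 log units; beyond the scatter) goes beyond it.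

Compound 4 `Cc1ccc(NC(=S)NC(=O)c2ccc(OCc3ccc(Cl)c(Cl)c3)cc2)cc1-c1nc2ccccc2[nH]1` has not yet been measured. It differs from compound 2 by 3,4-dichlorophenyl in place of 4-(trifluoromethyl)phenyl on a saturated chain carbon bound to an oxygen on an aromatic ring. Within the data shown here, two measured steps touch the same place, the saturated chain carbon bound to the oxygen on the aromatic ring. Between compound 1 and compound 2 the trifluoromethyl group gave a 1.6-fold lower number from compound 1 to compound 2 (0.21 log units; within the scatter), a step within the scatter. Between compound 2 and compound 3 the 3-fluorophenyl ring gave a 3.1-fold higher number from compound 2 to compound 3 (0.50 log units; beyond the scatter), a modest weakening, and a 1.9-fold higher number from compound 1 to compound 3 (0.28 log units; within the scatter) remained within the scatter. The halogenated rings thus all land near the unsubstituted one, and nothing here separates two chlorines from a trifluoromethyl group. For compound 4 the expected step is a 1.3-fold higher number from compound 2 to compound 4 (0.10 log units; within the scatter), with no change beyond the scatter foreseen in this assay. Compound 4 is estimated to give 22000 nM in this assay, within a range from 9000 nM to 55000 nM.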

Compound 4, half-maximal inhibitory concentration: 6270 nM
Estimate against measurement, compound 4: 3.5-fold (0.55 log units) above, outside the stated range (below it).
By their numbers in this assay, from the lowest: compound 4; then compounds 2, 1 and 3 (each within the scatter of the next, the first and the last beyond it).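

In this assay, this position now gives a step from the unsubstituted phenyl ring that goes beyond the scatter, a 4.6-fold lower number from compound 1 to compound 4 (0.66 log units; beyond the scatter), which neither the trifluoromethyl nor the fluoro ring gave on its own. The 3,4-dichlorophenyl ring also stands apart from the other two substituted rings, with a 2.8-fold lower number from compound 2 to compound 4 (0.45 log units; beyond the scatter) and an 8.8-fold lower number from compound 3 to compound 4 (0.95 log units; beyond the scatter), so compound 4 is the strongest of the four here, and halogen-bearing rings do not act as one group at this position: compound 2 and compound 3 go against any such rule, each staying within the scatter of compound 1. Nothing shown here explains why this ring differs from the others.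

The compounds shown leave open whether both chlorines are needed, since a ring with a single chlorine, such as 4-chlorophenyl or 3-chlorophenyl, would separate the contribution of each. They also leave open how this position responds to groups of a different kind on the same ring, such as a methoxy group, an amine or a carboxylic acid.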